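The source may report more compounds than this note shows. Statements on the series, on what has been measured and on what is new or still open speak of the compounds shown alone.

Working notes on the series.

Of the compounds shown here, three have been measured in a functional assay on HCT-116 cells (Homo sapiens) for inhibition, read by MTT assay, with a stated time of 2 days, tested at 10 uM; a higher number here means more inhibition at the concentration tested (going by the name of the read-out), a lower number less inhibition. Compound 1 `O=C(OCCCc1ccccc1)c1cc(-n2cc(-c3cccc(O)c3)nn2)ccc1O` gives 11% in this assay. Compound 2 `COC(=O)c1cc(-n2cc(-c3cc(O)ccc3O)nn2)ccc1O` gives 15% in this assay, and compound 3 `COc1ccc(-c2cn(-c3ccc(O)c(C(=O)O)c3)nn2)cc1` gives 8% in this assay. Compound 1 stands with the other two: its number differs from that of compound 3 and from that of compound 2 by gaps that both lie within the usual scatter, so no ordering among the three can be drawn, and all three read as weak inhibition at the concentration tested.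

The next compound, compound 4 `COc1cc(OC)cc(-c2cn(-c3ccc(O)c(C(=O)OCCCc4ccccc4)c3)nn2)c1`, is not yet measured. It keeps the ester and the rest of the core of compound 1 and differs only at the aromatic carbon of the five-membered ring: 3,5-dimethoxyphenyl in place of 3-hydroxyphenyl on an aromatic carbon

Among the measured compounds shown here, no step between measured compounds exists to guide this change. Given that compound 1 reads 11% and that compound 2 and compound 3 sit in the same low range, the step expected from compound 1 to compound 4 is a number 1 percentage points higher from compound 1 to compound 4 (within the scatter), none beyond the scatter. Compound 4 is therefore estimated at 12%, with a range of 0% to 30%.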

Compound 4, a percentage reported as inhibition, at one concentration (the size of the read-out at that concentration, not a potency): 19%
Estimate against measurement, compound 4: 7 percentage points below; the range from low to high includes it.
By their numbers in this assay, from the lowest: compounds 3, 1, 2 and 4 (each within the scatter of the next, the first and the last beyond it).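

In this assay, among the compounds shown here, 3,5-dimethoxyphenyl in place of 3-hydroxyphenyl on the aromatic carbon of the five-membered ring gives a number 8 percentage points higher from compound 1 to compound 4 (within the scatter), the first step that changes one place only. This position therefore accepts loss of the hydroxyl and entry of the two methoxy groups with no change that can be told from the scatter, so the hydroxyl of compound 1 is not required for the weak inhibition seen at the concentration tested. No measurement bears on what lies behind this step.

As far as these compounds go, it remains open whether an amine or a fluorine on this phenyl ring would move the number beyond the scatter. For the compounds shown here, also open is what a longer chain in the ester would do, as no pair here isolates that part.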